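Thiophene sulfonamide urea and thiourea pair: cytotoxicity notes

The compounds below may be only part of what the source reports. "The series", "measured", "known", "first", "only" and "open" are said of these compounds alone.

Compound 2 `COc1ccc(Oc2ccc(C(C)C)cc2-c2ccsc2S(=O)(=O)NCCNC(=O)Nc2cc(Cl)cc(Cl)c2)cc1OC` and compound 1 `COc1ccc(Oc2ccc(C(C)C)cc2-c2ccsc2S(=O)(=O)NCCNC(=S)Nc2ccc([N+](=O)[O-])cc2)cc1OC` share one core and differ only in the group on the chain amine. In an ADME assay on HEK-293T cells (Homo sapiens) for cytotoxicity, read by CCK-8 assay, with a stated time of 48 h (a lower number here means a stronger inhibitor, a higher number a weaker inhibitor), compound 2 gives 11900 nM. In the same assay compound 1 gives 11400 nM. The change is a group of 12 heavy atoms (7 carbon, 2 nitrogen, 2 oxygen, 1 sulfur; one six-membered aromatic ring of carbon only) in place of a group of 11 heavy atoms (7 carbon, 1 nitrogen, 1 oxygen, 2 chlorine; one six-membered aromatic ring of carbon only), on an amine nitrogen, and it gave a 1.0-fold lower number from compound 2 to compound 1 (0.02 log units; within the scatter), so the two values sit together. Compound 3 `O=C(NCCNS(=O)(=O)c1ccc(-c2ccccc2O[C@H]2CC[C@H](O)CC2)s1)Nc1cc(Cl)cc(Cl)c1` carries a different core; how its core differs from that of compound 2 is not broken down here. For compound 3 this assay gives only a limit, > 50000 nM, the same limit as the limit of > 50000 nM in this assay, at which 1 of the 3 values shown sits. Compound 4 `O=[N+]([O-])c1ccc(NC(=S)NCCNS(=O)(=O)c2ccc(-c3ccccc3O[C@H]3CC[C@H](O)CC3)s2)cc1` is not yet measured; it stands to compound 3 as compound 1 stands to compound 2, the change being (a group of 12 heavy atoms (7 carbon, 2 nitrogen, 2 oxygen, 1 sulfur; one six-membered aromatic ring of carbon only) in place of a group of 11 heavy atoms (7 carbon, 1 nitrogen, 1 oxygen, 2 chlorine; one six-membered aromatic ring of carbon only), on an amine nitrogen), at the same place and of the same kind. For compound 4 the step that the limit leaves unreadable from compound 3 to compound 4 is expected to be small, because the same change gave a 1.0-fold lower number from compound 2 to compound 1 (0.02 log units; within the scatter). Compound 4 is therefore estimated at 60000 nM, with 30000 nM to 150000 nM as the expected span, most likely reported again as a limit.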

Compound 4, half-maximal inhibitory concentration: 10500 nM
Beside the measured number, compound 4's estimate is 5.7-fold (0.76 log units) above it; measured number below the stated range.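

In this assay the change gave an at least 4.7-fold lower number from compound 3 to compound 4 (0.67 log units; beyond the scatter), while on the core of compound 2 it gave a 1.0-fold lower number from compound 2 to compound 1 (0.02 log units; within the scatter), so the size of the step did not carry from one core to the other: the same change on two cores in this assay, a 1.0-fold lower number (0.02 log units; within the scatter) from compound 2 to compound 1 and an at least 4.7-fold lower number (0.67 log units; beyond the scatter) from compound 3 to compound 4, at least 4.5-fold (0.65 log units) apart, beyond the scatter of two such steps
From the compounds shown here alone, for compound 3 the assay gives only a limit, > 50000 nM, so the step to compound 4 is a minimum and its full size remains unknown. These two pairs show that the change can behave differently on two cores, but they do not show which part of the cores sets the difference or what the change would do on a third core.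

The entering group differs from the (3,5-dichlorophenyl)carbamoyl group in both its sulfur and its nitro group, so the compounds shown do not assign the step to either feature. A (3,5-dichlorophenyl)thiocarbamoyl group on each core would separate the two, and a longer chain would test whether the step persists with more distance from the sulfonamide.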